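The source may hold more compounds than are shown below. What is called first, only, known or untested is meant among the compounds shown, and "the series" means these compounds.

Measured compounds:
Compound 1, `COc1cccc(/C=C2\CCC/C(=C\c3ccc(OC)c(OC)c3)C2=O)c1`, 3700 nM in a functional assay on SW-620 cells (Homo sapiens) for cytotoxicity, read by MTT assay, with a stated time of 72 h; on this read-out lower numbers stand for stronger inhibition and higher numbers for weaker inhibition.
Compound 2, `COc1cc(/C=C2\CCC/C(=C\c3ccc(OC)c(OC)c3)C2=O)cc(OC)c1`, 2500 nM in this assay.

Among the two numbers in hand, compound 1 stands at the highest; its nearest neighbour is compound 2, and the two differ only within the usual scatter. Going by the values given here, the one measured step joins these two: a 1.5-fold lower number from compound 1 to compound 2 (0.17 log units; within the scatter), brought about by a methoxy in place of hydrogen on an aromatic carbon.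

The compound still to be measured is compound 3, `COc1cc(/C=C2\CCC/C(=C\c3ccc(OC)c(OC)c3)C2=O)ccc1O`. It differs from compound 1 by hydroxy in place of hydrogen on an aromatic carbon. Among the compounds with values here, only the step from compound 1 to compound 2 bears on this change, since it too adds one small group on an aromatic carbon of the shared core, and that step stayed within the scatter. Nothing in the numbers points to a larger movement for hydroxy in place of hydrogen. Compound 3 is therefore expected to sit close to compound 1, with a step of a 1.2-fold lower number from compound 1 to compound 3 (0.09 log units; within the scatter) that is not expected to exceed the scatter. Compound 3 is estimated at 3000 nM, within a range of 1200 nM to 7500 nM.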

Compound 3, half-maximal inhibitory concentration: 4500 nM
Estimate against measurement, compound 3: 1.5-fold (0.18 log units) below; low and high end bracket the measured number.
By their numbers in this assay, from the lowest: compounds 2, 1 and 3 (each within the scatter of the next).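

In this assay, the change from 3-methoxyphenyl to 4-hydroxy-3-methoxyphenyl gives a 1.2-fold higher number from compound 1 to compound 3 (0.09 log units; within the scatter) and so stays within the scatter, with the hydroxy placed ortho to a methoxy group and para to a large group. The earlier compounds shown here showed only the addition of a methoxy group, which brings no hydrogen-bond donor; this hydroxy brings one, and still no step beyond the scatter appears, so the three compounds cannot be put in a firm order on this read-out. Nothing measured here speaks to why this change leaves the number within the scatter.

The compounds shown leave open whether an amine, a carboxylic acid or a longer chain such as ethoxy in place of the hydroxy would produce a step beyond the scatter. They also leave open whether a hydroxy would stay within the scatter on a ring carrying no methoxy group, since here it appears only alongside one.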